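The source may hold more compounds than are shown below. What is called first, only, known or untested is meant among the compounds shown, and "the series" means these compounds.

Measured so far:
- compound 1, `CCCCCCCCCCCCn1nnc(C(C(=O)Nc2ccc(F)cc2F)c2ccccc2)n1`: 1%
- compound 2, `CCCCCCCCCCCCn1nnc(C(C(=O)Nc2c(C)nn(C)c2C)c2ccccc2)n1`: 66%

Of the compounds shown here, two have been measured in an assay on isolated protein for inhibition of sterol O-acyltransferase 1 (Mus musculus), tested at 0.1 uM; on this read-out lower numbers stand for less inhibition and higher numbers for more inhibition at the one concentration tested (going by the name of the read-out). Compound 1, carrying 2,4-difluorophenyl on the amide-type nitrogen, gives 1% in this assay. Among the measured compounds shown here, compound 2, with 1,3,5-trimethyl-1H-pyrazol-4-yl in that place, gives 66%, the higher of the two numbers; the only step in this set, a number 65 percentage points higher from compound 1 to compound 2 (beyond the scatter), is large and lies beyond the scatter. So the group on the amide-type nitrogen is the one place shown to move this read-out strongly.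

Compound 3, `CCCCCCCCCCCCn1nnc(C(C(=O)Nc2ccc3c(C)cc(C)nc3n2)c2ccccc2)n1`, has not been measured. It differs from compound 2 only in that place: a group of 12 heavy atoms (10 carbon, 2 nitrogen; 2 six-membered aromatic rings with 1 hetero atom each) in place of a group of 8 heavy atoms (6 carbon, 2 nitrogen; one five-membered aromatic ring with 2 hetero atoms), on an amide-type nitrogen. The entering group keeps the two hydrogen-bond acceptors and no donors but is a larger bicyclic aromatic rather than one five-membered ring. For the measured compounds named here, the single measured step shows that this position can swing the read-out by a great deal in either direction, while nothing measured tells which way a bicyclic group will go. The account therefore expects a step of a number 26 percentage points lower from compound 2 to compound 3 (beyond the scatter), most likely downward from the highest value in the set, with wide uncertainty. Compound 3 is estimated at 40%, within 5% to 80%.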

Compound 3, a percentage reported as inhibition, at one concentration (the size of the read-out at that concentration, not a potency): 49%
For compound 3 the middle estimate is 9 percentage points below the measured one; low and high end bracket the measured number.
By their numbers in this assay, from the lowest: compound 1; then compound 3; then compound 2.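

In this assay, replacing 1,3,5-trimethyl-1H-pyrazol-4-yl on the amide-type nitrogen with the larger group of two six-membered aromatic rings gives a number 17 percentage points lower from compound 2 to compound 3 (beyond the scatter), a modest step, while replacing 2,4-difluorophenyl with the same group gives a number 48 percentage points higher from compound 1 to compound 3 (beyond the scatter), a large one. A substantial read-out at this position is therefore not confined to the five-membered ring of compound 2: a bicyclic aromatic group with a quite different ring system keeps much of it, although it does not match compound 2, and among these three compounds both nitrogen-containing groups stand well above the difluorophenyl group. Nothing available explains these differences.

The three compounds do not separate the contribution of the ring nitrogens from that of the methyl groups, and a 2,4,6-trimethylphenyl or an unsubstituted pyridin-3-yl group on the amide-type nitrogen would bear directly on that question. They also leave open how this position behaves with a shorter chain than dodecyl on the shared core, and how these single-concentration numbers relate to potency.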